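One Aryl Swap, Repeated on a Second Partner

The source may report more compounds than this note shows. Statements on the series, on what has been measured and on what is new or still open speak of the compounds shown alone.

Measured so far:
- Compound 1 `COc1ccccc1-c1csc(N/N=C/c2ccc(F)c(F)c2)n1`: > 100000 nM, a limit of the assay
- Compound 2 `Fc1ccc(/C=N/Nc2nc(-c3cccc(Br)c3)cs2)cc1F`: 16700 nM
- Compound 3 `COc1ccccc1-c1csc(N/N=C/c2cc(OC)c(OC)c(Br)c2Br)n1`: > 100000 nM, a limit of the assay

In a functional assay on HepG2 cells (Homo sapiens) for inhibition, read by MTT assay, with a stated time of 48 h (on this read-out lower numbers stand for stronger inhibition and higher numbers for weaker inhibition), compound 1 reaches only a limit, > 100000 nM. Compound 2 gives 16700 nM in this assay. The change between them is 3-bromophenyl in place of 2-methoxyphenyl on an aromatic carbon, and it made an at least 5.9-fold lower number from compound 1 to compound 2 (0.77 log units; beyond the scatter).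

Compound 4 `COc1cc(/C=N/Nc2nc(-c3cccc(Br)c3)cs2)c(Br)c(Br)c1OC` has not been measured. It differs from compound 3 by 3-bromophenyl in place of 2-methoxyphenyl on an aromatic carbon, the same change, at a place described in the same words. The difference between the core of compound 1 and the core of compound 3 is not broken down here.

Because the limit of > 100000 nM in this assay, at which 2 of the 3 values shown sit, holds two of the three values, a clear number for compound 4 is uncertain. Still, the step to compound 4 is expected to be an at least 2.5-fold lower number from compound 3 to compound 4 (0.39 log units; beyond the scatter). Compound 4 is expected to give about 40000 nM, somewhere between 10000 nM and 100000 nM.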

Compound 4, half-maximal inhibitory concentration: > 100000 nM
Compound 4: no number, only a limit (the forecaster's own chance of this, stated with the estimate: 45%); middle value at least 2.5-fold (0.39 log units) from the limit.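

The step from compound 3 to compound 4 cannot be read, since both compounds reach only a limit of the assay: the limit of > 100000 nM in this assay, at which 3 of the 4 values shown sit.

The compounds shown leave open whether 3-bromophenyl in place of 2-methoxyphenyl changes the number at all on the core of compound 3.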